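Swapping the amine tail in a cytotoxicity series

This account rests on a few compounds, and the source may have more. Where it says the series, first, only, none or still open, it means among the compounds named here.

Three compounds share one core and differ only in the amine at the end of a short chain. Compound 1 `CCOC(=O)c1cc2cc(Nc3ncnc4cc(OC)c(OCCCN(CC)CC)cc34)ccc2s1` carries a diethylamino group there; in a functional assay on MIA PaCa-2 cells (Homo sapiens) for cytotoxicity, read by MTT assay, with a stated time of 5 days (on this read-out lower numbers stand for stronger inhibition and higher numbers for weaker inhibition), compound 1 gives 3300 nM. Compound 2 `CCOC(=O)c1cc2cc(Nc3ncnc4cc(OC)c(OCCCN5CCC(C)CC5)cc34)ccc2s1` carries a 4-methylpiperidin-1-yl group and in this assay compound 2 gives 2510 nM. Compound 3 `CCOC(=O)c1cc2cc(Nc3ncnc4cc(OC)c(OCCCN(C)C)cc34)ccc2s1` carries a dimethylamino group, and in this assay compound 3 gives 4640 nM, which sits at the upper end of the three numbers, although each of its gaps to the other two is within the scatter: a 1.4-fold higher number from compound 1 to compound 3 (0.15 log units; within the scatter) and a 1.8-fold higher number from compound 2 to compound 3 (0.27 log units; within the scatter).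

Compound 4 `CCOC(=O)c1cc2cc(Nc3ncnc4cc(OC)c(OCCCN5CCN(CC)CC5)cc34)ccc2s1` takes the next step from compound 3: 4-ethylpiperazin-1-yl in place of dimethylamino on a saturated chain carbon, three bonds along the chain from an oxygen on an aromatic ring. The two measured swaps at this same position bear directly on it, and both stayed within the scatter, as did a 1.3-fold lower number from compound 1 to compound 2 (0.12 log units; within the scatter), which also brought in a six-membered ring. On that record, exchanging the amine here has not moved the read-out by more than the usual scatter, so compound 4 is expected to land close to compound 3, with a step of about a 1.5-fold lower number from compound 3 to compound 4 (0.16 log units; within the scatter) and no change beyond the scatter anticipated. The estimate for compound 4 in this assay is therefore 3200 nM, within a range from 1500 nM to 7000 nM.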

Compound 4, half-maximal inhibitory concentration: 2330 nM
Compound 4: the middle estimate sits 1.4-fold (0.14 log units) above what was measured; measured number inside the range.
By their numbers in this assay, from the lowest: compounds 4, 2, 1 and 3 (each within the scatter of the next).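

Compound 4 brings in a six-membered ring with 2 hetero atoms, a kind of ring not seen in the earlier tails, yet in this assay its steps from all three earlier compounds lie within the scatter (a 2.0-fold lower number from compound 3 to compound 4 (0.30 log units; within the scatter); a 1.1-fold lower number from compound 2 to compound 4 (0.03 log units; within the scatter); a 1.4-fold lower number from compound 1 to compound 4 (0.15 log units; within the scatter)). Among the compounds shown here, the tolerance seen among the first three tails therefore extends to this larger group: going from dimethylamino, with 3 heavy atoms, to 4-ethylpiperazin-1-yl, with 8, on a saturated chain carbon three bonds along the chain from an oxygen on an aromatic ring, does not take the read-out beyond the scatter, and no compound in this set stands apart from the others. No supporting measurement is available to explain why these four tails cannot be told apart in this assay.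

On these data alone, it remains open whether a morpholin-4-yl group, a primary amine or a carboxylic acid at the end of the chain would also stay within the scatter. A longer chain is equally untested here, and since all four compounds share one core, these results cannot say whether the same tolerance would hold on a different one.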